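Series notes: the step from compound 1 to compound 4

The source may report more compounds than this note shows. Statements on the series, on what has been measured and on what is new or still open speak of the compounds shown alone.

Compound 1 `NC(=O)c1c(NC(=O)Nc2ccc(Cl)cc2)sc2c1CCN(C1CCOCC1)C2` has been measured in a functional assay (strain AB) with Danio rerio as the target, read by microscopy, with a stated time of 1 h (a higher number here means that more compound is needed for the effect, a lower number that less compound is needed), where compound 1 gives 2830 nM. Of the two numbers recorded so far, compound 1 holds the higher one; its nearest neighbour is compound 2 `CCN1CCc2c(sc(NC(=O)Nc3ccc4ccccc4c3)c2C(N)=O)C1`, which in this assay gives 1780 nM, a gap that lies within the scatter, so no order between compound 1 and compound 2 can be read from it. Compound 3 `CCN1CCc2c(sc(NC(=O)NCC3CCCO3)c2C(N)=O)C1` returns only a limit: in this assay compound 3 gives > 25000 nM, which is a limit of the assay and not a number (the limit of > 25000 nM in this assay, at which 1 of the 3 values shown sits).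

Compound 4 `NC(=O)c1c(NC(=O)Nc2ccc(Cl)cc2)sc2c1CCN(CC1CCCCC1)C2` has not yet been measured in this assay. It differs from compound 1 in one place (cyclohexylmethyl in place of oxan-4-yl on an amine nitrogen in a ring). Among the compounds with values here, no step between measured compounds covers this change, so no measured direction is available for it. The expectation for compound 4 is a step of a 1.3-fold lower number from compound 1 to compound 4 (0.11 log units; within the scatter), not beyond the scatter, in either direction. Compound 4 is therefore estimated at 2200 nM, with a range from 700 nM to 7000 nM.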

Compound 4, half-maximal effective concentration: 1890 nM
Beside the measured number, compound 4's estimate is 1.2-fold (0.07 log units) above it, within the range that was stated.
By their numbers in this assay, from the lowest: compounds 2, 4 and 1 (each within the scatter of the next). At a limit, above all of these: compound 3.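

Within the data shown here, the change gives the first step at this position in this assay: a 1.5-fold lower number from compound 1 to compound 4 (0.18 log units; within the scatter). On this amine nitrogen in a ring, all-carbon cyclohexylmethyl can therefore take the place of oxan-4-yl, with its ring oxygen and hydrogen-bond acceptor, without a difference that can be told from the scatter, at least for this pair. The compounds shown offer nothing that would give a cause for this small step.

On these data alone, whether a phenyl ring, a longer chain ending in an amine or a carboxylic acid on the same nitrogen would also stay within the scatter remains open. As far as these compounds go, with a single pair covering this change, it also remains open whether the same result would hold if another part of compound 1 were altered.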